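The source may hold more compounds than are shown below. What is called first, only, known or untested is meant among the compounds shown, and "the series" means these compounds.

Compound 3 `O=C(O)c1csc(SCCN2C(=O)CC[C@@H]2/C=C/[C@@H](O)Cc2cccc(-c3nc4ccccc4o3)c2)n1` gives 0.12 nM in an assay on CHO cells for displacement of a labelled ligand from prostaglandin E2 receptor EP4 subtype (Mus musculus), read by scintillation counting, with a stated time of 60 min; a lower number here means a stronger inhibitor, a higher number a weaker inhibitor. Compound 1 `O=C(O)CCCSCCN1C(=O)CC[C@@H]1/C=C/[C@@H](O)Cc1cccc(-c2ccc3[nH]ccc3c2)c1` gives 0.28 nM, and compound 2 `O=C(O)CCCSCCN1C(=O)CC[C@@H]1/C=C/[C@@H](O)Cc1cccc(-c2nc3ccccc3s2)c1` gives 0.36 nM. Of these three numbers, that of compound 3 is the lowest; compound 1 is its nearest neighbour and compound 2 the furthest, and both gaps are beyond the scatter. Among the compounds with values here, the only single-point step among the measured compounds, a 1.3-fold higher number from compound 1 to compound 2 (0.11 log units; within the scatter), is within the scatter: replacing the 1H-indol-5-yl by 1,3-benzothiazol-2-yl left the number essentially where it was.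

Compound 4 `Cc1cc(C)c2oc(-c3cccc(C[C@H](O)/C=C/[C@H]4CCC(=O)N4CCSc4nc(C(=O)O)cs4)c3)nc2c1` is compound 3 with 5,7-dimethyl-1,3-benzoxazol-2-yl in place of 1,3-benzoxazol-2-yl on an aromatic carbon. Within the data shown here, no measured pair here adds methyl groups to this ring system, so there is no direct precedent for the change. What the step from compound 1 to compound 2 does show is that exchanging the whole aromatic group at this position produced no shift beyond the scatter, and the present change keeps the 1,3-benzoxazol-2-yl intact and merely decorates it. On that basis no step beyond the scatter is expected in this assay. Compound 4 is therefore estimated at 0.15 nM, with a likely range from 0.05 nM to 0.5 nM, which would mean an expected step of a 1.3-fold higher number from compound 3 to compound 4 (0.10 log units; within the scatter).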

Compound 4, inhibition constant: 0.15 nM
Estimate against measurement, compound 4: no gap at the digits printed, within the range that was stated.
By their numbers in this assay, from the lowest: compounds 3, 4, 1 and 2 (each within the scatter of the next, the first and the last beyond it).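

Adding two methyl groups to the 1,3-benzoxazol-2-yl gave a 1.3-fold higher number from compound 3 to compound 4 (0.10 log units; within the scatter) in this assay, so this aromatic group can carry the two extra carbons with no shift beyond the scatter. The earlier step replaced one whole aromatic group with another on the core of compound 1, whereas this one keeps the group and decorates it on the core of compound 3, which extends the same flat result to a second core and a second kind of change. Nothing available here explains why the number stays in place.

The compounds shown leave open whether the 1,3-benzoxazol-2-yl would accept other groups as readily, such as a methoxy group, a chlorine atom, an amine or a carboxylic acid in place of the methyl groups. They also leave open whether a single methyl group would behave as the pair does, and whether a longer chain such as propyl or butyl on this ring would still leave the number where it is.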